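Removing a Second Benzoyl Ester: Solubility Outlook

The source may report more compounds than this note shows. Statements on the series, on what has been measured and on what is new or still open speak of the compounds shown alone.

Measured compounds:
- compound 1 `COc1ncnc2c1ncn2[C@@H]1O[C@H](COC(=O)c2ccccc2)[C@@H](OC(=O)c2ccccc2)[C@@H]1OC(=O)c1ccccc1`: 8000 nM
- compound 2 `COc1ncnc2c1ncn2[C@@H]1O[C@H](CO)[C@@H](OC(=O)c2ccccc2)[C@@H]1OC(=O)c1ccccc1`: 13000 nM

In a physicochemical assay for solubility, in phosphate buffer (on this read-out higher numbers stand for higher solubility and lower numbers for lower solubility), compound 1 gives 8000 nM and compound 2 gives 13000 nM. Among the compounds with values here, the only measured neighbour of compound 1 is compound 2, and the step of a 1.6-fold higher number from compound 1 to compound 2 (0.21 log units; within the scatter) sits within the scatter, so the two numbers cannot be told apart. The unmeasured compound 3 `COc1ncnc2c1ncn2[C@@H]1O[C@H](COC(=O)c2ccccc2)[C@@H](O)[C@@H]1OC(=O)c1ccccc1` differs from compound 1 by hydrogen in place of benzoyl on an oxygen on a saturated carbon. Within the data shown here, the single step that bears on this change is the one from compound 1 to compound 2, where a benzoyl was likewise exchanged for hydrogen on an oxygen on a saturated carbon, with the result a 1.6-fold higher number from compound 1 to compound 2 (0.21 log units; within the scatter). Among the measured compounds shown here, only one such step is known, and its size stayed within the scatter, so no movement beyond the scatter is expected for compound 3 either. Compound 3 is therefore expected to give 12000 nM, with a range from 5000 nM to 30000 nM. The expected step of a 1.5-fold higher number from compound 1 to compound 3 (0.18 log units; within the scatter) is estimated to remain within the usual scatter of this assay.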

Compound 3, solubility: < 5000 nM
Compound 3: only a limit was reported (the forecaster's own chance of this, stated with the estimate: 5%); middle value at least 2.4-fold (0.38 log units) from the limit.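

In this assay compound 3 gives < 5000 nM, which is a limit of the assay and not a number. The earlier compounds shown here showed the exchange of benzoyl for hydrogen only at a different oxygen, in a 1.6-fold higher number from compound 1 to compound 2 (0.21 log units; within the scatter), whereas at this position, benzoyloxy to hydroxy on a saturated carbon whose other neighbours are saturated ring carbon, the reading is an at least 1.6-fold lower number from compound 1 to compound 3 (0.20 log units; that floor lies within the scatter). The result thus places compound 3 on the lower side of compound 1 rather than the higher side expected from that one earlier step, but only as a floor, and the full size of the step stays unread, as the number for compound 3 ends at a limit: the limit of < 5000 nM in this assay, at which 1 of the 3 values shown sits.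

The compounds shown leave open how far compound 3 truly lies from compound 1, and whether that distance exceeds the scatter at all. They also leave open what a group other than benzoyl or hydrogen on this oxygen, such as an acetyl, an aminoalkyl chain carrying an amine or a chain ending in a carboxylic acid, would give on this read-out, and whether it would return a number rather than a limit.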